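Adding a (Piperidin-1-yl)methyl Group: What to Expect

This account rests on a few compounds, and the source may have more. Where it says the series, first, only, none or still open, it means among the compounds named here.

Compound 1, `COc1cc(OC)c(C(=O)c2cccc(Cl)c2)c(O)c1CN1CCCCC1`: 83%
Compound 2, `COc1cc(O)c(C(=O)c2ccccc2Br)c(OC)c1`: 72%

Of the compounds shown here, two have so far been measured in a functional assay on THP-1 cells (Homo sapiens) for inhibition, read by ELISA, with stated times of 30 min and 24 h, tested at 10 uM; a higher number here means a stronger effect of the compound at the concentration tested, a lower number a weaker effect. Compound 1 gives 83%, and compound 2 gives 72%. Of these two numbers, compound 2 stands lowest; its nearest neighbour is compound 1, whose reading is higher by a margin beyond the usual scatter of this kind of measurement.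

Compound 3, `COc1cc(OC)c(C(=O)c2ccccc2Br)c(O)c1CN1CCCCC1`, has not yet been measured. It differs from compound 2 in a single place: (piperidin-1-yl)methyl in place of hydrogen on an aromatic carbon. Among the compounds with values here, compound 1 and compound 2 differ in more than one place, so no single step between them can be drawn; their two values show only that compound 1, which carries the same (piperidin-1-yl)methyl group, gives the higher reading.

On that basis, the step from compound 2 to compound 3 in this assay is expected to be upward and modest, close to the edge of the scatter, estimated as a number 8 percentage points higher from compound 2 to compound 3 (within the scatter). Compound 3 is expected to give about 80%, within an estimated range from 65% to 92%, because compound 1 gives 83%.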

Compound 3, a percentage reported as activity, at one concentration (the size of the read-out at that concentration, not a potency): 98%
Estimate against measurement, compound 3: 18 percentage points below, and the stated range ends below it.
By their numbers in this assay, from the lowest: compound 2; then compound 1; then compound 3.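

In this assay, within the data shown here, the (piperidin-1-yl)methyl group in place of hydrogen on this aromatic carbon, ortho to a hydroxy group and para to a methoxy group, gives a number 26 percentage points higher from compound 2 to compound 3 (beyond the scatter) as the first clean single-change reading at this position. With that group held in place, 2-bromophenyl in place of 3-chlorophenyl on a carbonyl carbon gives a number 15 percentage points higher from compound 1 to compound 3 (beyond the scatter) in this assay, so the reading at this position is not the only one that moves the result: the group on the carbonyl counts as well. Nothing measured here explains why either change raises the reading.

Each of these steps is a single example, read at one concentration, so neither shows how the same change would behave on another part of the core or how potency would shift. Also open, as far as these compounds go, is whether the ring of the piperidine matters or whether a smaller open-chain amine such as (dimethylamino)methyl, a morpholine ring or a carboxylic acid on the same aromatic carbon would give a similar reading.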